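Ethyl to cyano on the methoxy-bearing ring

The source may report more compounds than this note shows. Statements on the series, on what has been measured and on what is new or still open speak of the compounds shown alone.

- compound 1 `COc1ccc(C(C)=O)cc1COc1cccc(C)c1` gives 2800 nM
- compound 2 `CCc1ccc(OC)c(COc2ccc(Cl)c(C)c2)c1` gives 40000 nM
- compound 3 `COc1ccc(C(N)=O)cc1COc1ccc(Cl)cc1` gives 660 nM

For the measured compounds named here, all three values come from a functional assay on HUVEC cells (Homo sapiens) for inhibition, with a stated time of 4 days (on this read-out higher numbers stand for weaker inhibition and lower numbers for stronger inhibition), and are the only data so far. Compound 2 stands highest of the three and is therefore the weakest inhibitor here, with compound 1 nearest to it and compound 3 furthest away.

Compound 4 `COc1ccc(C#N)cc1COc1ccc(Cl)c(C)c1` differs from compound 2 in one place (cyano in place of ethyl on an aromatic carbon), para to a methoxy group.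

Going by the values given here, no measured pair differs in one place only, so this step has no direct precedent. Neither compound 1 (2800 nM) nor compound 3 (660 nM) carries ethyl at that place, and both show lower numbers than compound 2, although they also differ elsewhere. A large step towards a lower number in this assay is therefore expected, beyond the scatter. The estimated change is a 20-fold lower number from compound 2 to compound 4 (1.30 log units; beyond the scatter) and remains uncertain. For compound 4 the expected value is 2000 nM (range 400 nM to 10000 nM).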

Compound 4, half-maximal inhibitory concentration: 1500 nM
The estimate for compound 4 lay 1.3-fold (0.12 log units) above the measured number; measured number inside the range.
By their numbers in this assay, from the lowest: compound 3; then compounds 4 and 1 (each within the scatter of the next); then compound 2.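

In this assay, this position now has a direct comparison in one place: cyano in place of ethyl on the aromatic carbon para to a methoxy group gives a 27-fold lower number from compound 2 to compound 4 (1.43 log units; beyond the scatter) as the step. The earlier compounds shown here could not show this, since no two of them differed in one place only, and it establishes that the number here responds strongly to the group at this position. Ethyl and cyano have the same heavy-atom count, so the step comes without a change in that count; what enters is a triple bond and a hydrogen-bond acceptor.

From the compounds shown here alone, whether another group at this place, such as a carboxylic acid or a primary amine, would give a similar step remains open, as does whether the step carries over to the other compounds. Nothing measured here accounts for the size of the step.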